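Substituent on the ring nitrogen of the shared core: propargyl to isopentyl

This account rests on a few compounds, and the source may have more. Where it says the series, first, only, none or still open, it means among the compounds named here.

Measured compounds:
Compound 1, `O=C(Nc1ncc(-c2cccc(Cl)c2)c(-c2ccccc2)n1)C1CCC1`: 52%
Compound 2, `Clc1cccc(-c2cnc(Nc3ccccc3)nc2-c2ccccc2)c1`: 34%
Compound 3, `C#CCNc1ncc(-c2cccc(Cl)c2)c(-c2ccccc2)n1`: 76%

In an assay on CHO cells for displacement of a labelled ligand from adenosine receptor A1 (Homo sapiens), read by scintillation counting, with a stated time of 1 h, tested at 1 uM (on this read-out higher numbers stand for more inhibition at the one concentration tested (going by the name of the read-out) and lower numbers for less inhibition), compound 3 stands highest of the three numbers; its nearest neighbour is compound 1, a number 24 percentage points higher from compound 1 to compound 3 (beyond the scatter), and its furthest compound 2, a number 42 percentage points higher from compound 2 to compound 3 (beyond the scatter). Compound 4, `CC(C)CCNc1ncc(-c2cccc(Cl)c2)c(-c2ccccc2)n1`, is not yet measured. It differs from compound 3 as follows: isobutyl in place of ethynyl on a saturated chain carbon bound to a nitrogen on an aromatic ring.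

The measured steps all exchange the whole group on the ring nitrogen, a number 18 percentage points lower from compound 1 to compound 2 (beyond the scatter) and a number 24 percentage points higher from compound 1 to compound 3 (beyond the scatter); none of them exchanges one saturated chain for another, and none removes a triple bond while keeping an alkyl chain. Propargyl gave the highest number of the three nitrogen substituents, so moving away from it is expected to cost something, but the step is without a direct precedent. A modest decrease is estimated, a number 18 percentage points lower from compound 3 to compound 4 (beyond the scatter), with a wide range. Compound 4 is expected to give about 58%, between 35% and 82%.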

Compound 4, a percentage reported as inhibition, at one concentration (the size of the read-out at that concentration, not a potency): 39%
Beside the measured number, compound 4's estimate is 19 percentage points above it, within the range that was stated.
By their numbers in this assay, from the lowest: compounds 2 and 4 (each within the scatter of the next); then compound 1; then compound 3.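

In this assay a saturated chain on the ring nitrogen does not keep the number of the propargyl compound: isobutyl in place of ethynyl is a large step (a number 37 percentage points lower from compound 3 to compound 4 (beyond the scatter)). Isopentyl also gives no gain over the other nitrogen substituents (a number 5 percentage points higher from compound 2 to compound 4 (within the scatter); a number 13 percentage points lower from compound 1 to compound 4 (beyond the scatter)), which leaves propargyl set apart from all three, with cyclobutylcarbonyl the only other group beyond the scatter from phenyl. No available evidence bears on the reason for this fall.

The step changes both the triple bond and the chain length at once, and the compounds shown leave open which of the two matters; a propyl group on the nitrogen would help to separate them. On these data alone, what a hydroxyl or an amine at the end of the chain would do in this assay also remains open.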